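Swapping 4-chlorophenyl for 3-fluorophenyl in compound 3

The compounds below may be only part of what the source reports. "The series", "measured", "known", "first", "only" and "open" are said of these compounds alone.

Compound 1 `CC(C)OC(=O)C1CN(C(=O)c2cccc(Cl)c2)CC(C)(C)c2cc(C#N)[nH]c21` gives 17 ug/mL in a physicochemical assay for solubility, at pH 7.4; on this read-out higher numbers stand for higher solubility and lower numbers for lower solubility
Compound 2 `CC(C)OC(=O)C1CN(C(=O)C2CCCCC2)CC(C)(C)c2cc(C#N)[nH]c21` gives > 100 ug/mL which is a limit of the assay
Compound 3 `CC(C)OC(=O)C1CN(C(=O)c2ccc(Cl)cc2)CC(C)(C)c2cc(C#N)[nH]c21` gives 5 ug/mL in this assay

Compound 3 stands lowest of the two actual numbers. Compound 4 `CC(C)OC(=O)C1CN(C(=O)c2cccc(F)c2)CC(C)(C)c2cc(C#N)[nH]c21` differs from it on a carbonyl carbon 3-fluorophenyl in place of 4-chlorophenyl on a carbonyl carbon with 3-fluorophenyl in place of 4-chlorophenyl. The closest measured change is a 3.4-fold lower number from compound 1 to compound 3 (0.53 log units; beyond the scatter) and it is modest. The cyclohexyl changes an at least 5.8-fold higher number from compound 1 to compound 2 (0.76 log units; beyond the scatter) and an at least 20-fold lower number from compound 2 to compound 3 (1.30 log units; beyond the scatter) are larger, but compound 4 has no cyclohexyl. Compound 1 at 17 ug/mL carries 3-chlorophenyl, the nearest match to 3-fluorophenyl, so a modest rise is expected in this assay overall. The expected change is a 4.0-fold higher number from compound 3 to compound 4 (0.60 log units; beyond the scatter) in this estimate. For compound 4 the estimate is 20 ug/mL with an expected range of 8 ug/mL to 50 ug/mL in this assay here.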

Compound 4, solubility: > 100 ug/mL
Compound 4 ended at the assay's limit; the forecaster's own chance of this, stated with the estimate: 5%; middle value at least 5.0-fold (0.69 log units) away from the limit.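

In this assay, the change on this carbonyl carbon gives an at least 20-fold higher number from compound 3 to compound 4 (1.30 log units; beyond the scatter), and fluoro in place of chloro on an aromatic carbon alone gives an at least 5.8-fold higher number from compound 1 to compound 4 (0.76 log units; beyond the scatter). Until now only the cyclohexyl of compound 2 had reached the top of the range; compound 4 shows that a compound with an aromatic ring here can reach it too, and that the halogen alone can decide this. Compound 4 sits at a limit of this assay, as compound 2 does: the limit of > 100 ug/mL in this assay, at which 2 of the 4 values shown sit.

From the compounds shown here alone, the step between compound 2 and compound 4 cannot be read, so how these two compare stays open. Also open, going by these compounds, is whether a phenyl ring carrying an amine or a carboxylic acid would behave the same way at this position.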